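A few compounds are considered here, and "the series" means these few. Any claim that something is new, unique, unknown or untested is made for them only; others in the source may bear on it.

Three compounds that share one core are compared in an assay on cells for inhibition of protein deacetylase HDAC6 (Homo sapiens), with a stated time of 3 h; on this read-out higher numbers stand for weaker inhibition and lower numbers for stronger inhibition. Compound 1 `COc1ccc(Nc2ncnc3cc(NC(=O)CCCCCCC(=O)NO)sc23)c(C)c1` gives 111 nM. Compound 2 `C#Cc1cccc(Nc2ncnc3cc(NC(=O)CCCCCCC(=O)NO)sc23)c1` gives 21.3 nM, and compound 3 `N#Cc1cccc(Nc2ncnc3cc(NC(=O)CCCCCCC(=O)NO)sc23)c1` gives 20.1 nM. Among the three, compound 3 stands at the lowest number; the gap a 1.1-fold lower number from compound 2 to compound 3 (0.03 log units; within the scatter) is within the scatter, while the gap a 5.5-fold lower number from compound 1 to compound 3 (0.74 log units; beyond the scatter) lies beyond it. Compound 4 `CCc1ccc(Nc2ncnc3cc(NC(=O)CCCCCCC(=O)NO)sc23)cc1` has not yet been measured in this assay. It differs from compound 3 in one place: 4-ethylphenyl in place of 3-cyanophenyl on a nitrogen on an aromatic ring. Within the data shown here, two measured steps bear on this change. The step of a 5.5-fold lower number from compound 1 to compound 3 (0.74 log units; beyond the scatter) shows that a move from one substituted phenyl ring to 3-cyanophenyl lowered the number by a modest but real margin, and the step of a 1.1-fold lower number from compound 2 to compound 3 (0.03 log units; within the scatter) shows that swapping cyano for ethynyl on that ring changed nothing beyond the scatter. The 4-ethylphenyl ring carries neither cyano nor ethynyl, the groups present in compound 3 and compound 2, and the only other ring measured, in compound 1, gave the highest number. A step back toward the number of compound 1 is therefore expected for compound 4, smaller than that full gap, as a 2.2-fold higher number from compound 3 to compound 4 (0.35 log units; beyond the scatter). Compound 4 is estimated at 45 nM, with a range from 18 nM to 120 nM.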

Compound 4, half-maximal inhibitory concentration: 98.3 nM
For compound 4 the middle estimate is 2.2-fold (0.34 log units) below the measured one; the range from low to high includes it.
By their numbers in this assay, from the lowest: compounds 3 and 2 (each within the scatter of the next); then compounds 4 and 1 (each within the scatter of the next).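

In this assay, the step of a 4.9-fold higher number from compound 3 to compound 4 (0.69 log units; beyond the scatter) and the step of a 4.6-fold higher number from compound 2 to compound 4 (0.66 log units; beyond the scatter) show that, on a nitrogen on an aromatic ring, the 3-cyanophenyl and 3-ethynylphenyl results do not extend to 4-ethylphenyl, even though 4-ethylphenyl has the same heavy-atom count as 3-cyanophenyl. The step of a 1.1-fold lower number from compound 1 to compound 4 (0.05 log units; within the scatter) stays within the scatter, so 4-ethylphenyl and 4-methoxy-2-methylphenyl cannot be told apart, and the four compounds fall into two groups rather than a graded series. Nothing available here explains this split.

The compounds shown leave open whether the split follows the group itself or where it sits on the phenyl ring, as the two lower-number rings are 3-substituted and the two higher-number rings carry a group at 4; a 3-ethylphenyl ring and a 4-cyanophenyl ring would separate these readings. Also open, going by these compounds, is how a phenyl ring bearing an amine or a carboxylic acid would read at this place.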